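The source may report more compounds than this note shows. Statements on the series, on what has been measured and on what is new or still open speak of the compounds shown alone.

Three carbamates carrying the same selenocyanate-bearing core have been tested in a functional assay on PC-3 cells (Homo sapiens) for cytotoxicity, read by MTT assay, with a stated time of 72 h; on this read-out lower numbers stand for stronger inhibition of growth and higher numbers for weaker inhibition of growth. Compound 1 `CCCOC(=O)Nc1ccc([Se]C#N)cc1` gives 21100 nM, compound 2 `C=CCOC(=O)Nc1ccc([Se]C#N)cc1` gives 17600 nM, and compound 3 `N#C[Se]c1ccc(NC(=O)Oc2ccc(F)cc2)cc1` gives 11800 nM. Among the measured compounds shown here, the one single-change step measured so far, a 1.2-fold lower number from compound 1 to compound 2 (0.08 log units; within the scatter), stays within the scatter. Compound 3 holds the lowest of the three numbers, yet its gaps to compound 2 and to compound 1 both lie within the scatter, so no ranking among the three can be claimed.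

Compound 4 `N#C[Se]c1ccc(NC(=O)Oc2ccccc2)cc1` differs from compound 3 by hydrogen in place of fluoro on an aromatic carbon. For the measured compounds named here, no measured step touches the aryl carbamate end of the molecule; the only step known, a 1.2-fold lower number from compound 1 to compound 2 (0.08 log units; within the scatter), concerns the alkyl chain and is itself within the scatter. On that basis compound 4 is expected to give about 12500 nM in this assay, a range of 6000 nM to 26000 nM. The step from compound 3 to compound 4 is therefore estimated as a 1.1-fold higher number from compound 3 to compound 4 (0.03 log units; within the scatter), not beyond the scatter.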

Compound 4, concentration for 50% growth inhibition: 9100 nM
The estimate for compound 4 lay 1.4-fold (0.14 log units) above the measured number; the measured number falls inside the stated range.
By their numbers in this assay, from the lowest: compounds 4, 3, 2 and 1 (each within the scatter of the next, the first and the last beyond it).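

At the aromatic carbon para to a large group, hydrogen in place of fluoro gives a 1.3-fold lower number from compound 3 to compound 4 (0.11 log units; within the scatter) in this assay, so the fluoro group is not required for the growth inhibition seen with compound 3. Among the compounds shown here, on the oxygen next to a carbonyl group, phenyl in place of allyl gives a 1.9-fold lower number from compound 2 to compound 4 (0.29 log units; within the scatter) and stays short of a clear separation, whereas phenyl in place of propyl gives a 2.3-fold lower number from compound 1 to compound 4 (0.37 log units; beyond the scatter) and is the first step here to pass the scatter, though only modestly. Nothing measured on these compounds explains either result.

Going by these compounds, whether chloro, methoxy or an amine at that aromatic carbon would shift the number beyond the scatter remains open. So does how a longer chain on that oxygen would compare with propyl.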